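The source may hold more compounds than are shown below. What is called first, only, known or untested is meant among the compounds shown, and "the series" means these compounds.

Measured so far in a functional assay on HeLa cells (Homo sapiens) for inhibition, read by MTT assay, with a stated time of 72 h; a lower number here means a stronger inhibitor, a higher number a weaker inhibitor:
compound 1, `CN(C(=O)NC(=O)c1ccc(F)c(F)c1)c1nc(C(F)(F)F)c(C(=O)N/N=C/c2ccccc2C(F)(F)F)s1`, 9.24 ug/mL
compound 2, `Cc1nc(N(C)C(=O)NC(=O)c2c(F)cccc2F)sc1C(=O)N/N=C/c1cccc(C(F)(F)F)c1`, 26.8 ug/mL
compound 3, `CN(C(=O)NC(=O)c1ccc(F)c(F)c1)c1nc(C(F)(F)F)c(C(=O)N/N=C/c2cccc(C(F)(F)F)c2)s1`, 4.21 ug/mL

Compound 3 gives the lowest number of the three in this assay. Compound 1 carries one change on the core of compound 3, (2-(trifluoromethyl)phenyl in place of 3-(trifluoromethyl)phenyl on a carbon with a double bond to nitrogen), and this brings a 2.2-fold higher number from compound 3 to compound 1 (0.34 log units; beyond the scatter), a modest step beyond the usual scatter. Compound 2 stands on a different core; how its core differs from that of compound 3 is not broken down here. Compound 2 gives the highest number of the three, and both its values against compound 1 and against compound 3 lie beyond the scatter.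

Compound 4, `Cc1nc(N(C)C(=O)NC(=O)c2c(F)cccc2F)sc1C(=O)N/N=C/c1ccccc1C(F)(F)F`, is not yet measured. It carries on compound 2 the change (2-(trifluoromethyl)phenyl in place of 3-(trifluoromethyl)phenyl on a carbon with a double bond to nitrogen), the same change that turns compound 3 into compound 1. Going by the values given here, compound 4 is therefore expected to show a 2.1-fold higher number from compound 2 to compound 4 (0.31 log units; beyond the scatter), a step of about the size seen from compound 3 to compound 1, because a 2.2-fold higher number from compound 3 to compound 1 (0.34 log units; beyond the scatter) is the only measured instance of this change. The expected value for compound 4 in this assay is 55 ug/mL, within 22 ug/mL to 140 ug/mL.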

Compound 4, half-maximal inhibitory concentration: 6.51 ug/mL
Compound 4: middle estimate off by 8.4-fold (0.93 log units), on the high side; the whole stated range lies above it.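

Putting 2-(trifluoromethyl)phenyl in place of 3-(trifluoromethyl)phenyl on a carbon with a double bond to nitrogen gives a 4.1-fold lower number from compound 2 to compound 4 (0.61 log units; beyond the scatter) in this assay, so the earlier step does not carry over to this core in direction or in size. Set side by side, the two steps disagree: the same change on two cores in this assay, a 2.2-fold higher number (0.34 log units; beyond the scatter) from compound 3 to compound 1 and a 4.1-fold lower number (0.61 log units; beyond the scatter) from compound 2 to compound 4, 9.0-fold (0.96 log units) apart, beyond the scatter of two such steps. This shows that, in these two pairs, the outcome of the change depends on the core that carries it, but it does not show which difference between the two cores is responsible, and two pairs set no rule for the wider series.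

The compounds shown leave open how the same change behaves on cores that differ from these in one place only, which would be needed to tie the reversal to a single group. Also open, as far as these compounds go, is how a nitrile or a methoxy group would compare with trifluoromethyl on the phenyl ring of either core.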